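A few compounds are considered here, and "the series" means these few. Any claim that something is new, unique, unknown or untested is made for them only; others in the source may bear on it.

Measured in a physicochemical assay for lipophilicity, read by HPLC, at pH 7.5; a higher number here means a more lipophilic compound, a lower number a more polar compound:
- compound 1 `CCOc1ccccc1-c1ccc(-c2nc3cnccc3c(NC(C)C(=O)O)c2C#N)cc1`: 2.1
- compound 2 `CCOc1ccccc1-c1ccc(-c2nc3cnccc3c(N[C@H](CC)C(=O)N(C)C)c2C#N)cc1`: 3.7
- compound 3 `CCOc1ccccc1-c1ccc(-c2nc3cnccc3c(C[C@H](C)C(N)=O)c2C#N)cc1`: 3

Compound 3 is the second highest of these three numbers. It stands clear of both neighbours, with a number 0.90 log units higher from compound 1 to compound 3 (beyond the scatter) and a number 0.70 log units lower from compound 2 to compound 3 (beyond the scatter).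

The next step leads to compound 4 `CCOc1ccccc1-c1ccc(-c2nc3cnccc3c(N[C@H](CC)C(=O)O)c2C#N)cc1`, which carries (1-carboxypropyl)amino in place of 2-carbamoylpropyl on an aromatic carbon, ortho to a cyano group and opposite the ring nitrogen ((1-carboxypropyl)amino in place of 2-carbamoylpropyl on an aromatic carbon).

The closest evidence is compound 1, which carries (1-carboxyethyl)amino at this place and is separated from compound 3 by the modest a number 0.90 log units higher from compound 1 to compound 3 (beyond the scatter). Running that step backwards suggests a fall. Compound 2 has the same propyl chain as compound 4 but ends in dimethylcarbamoyl instead of carboxy, and the large a number 1.60 log units higher from compound 1 to compound 2 (beyond the scatter) shows how far a carboxy compound can lie from that amide. Among the compounds with values here, no measured pair isolates the difference between the ethyl and propyl chains, so compound 4 is expected to lie a little above compound 1, though this is uncertain.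

A modest fall in this assay is therefore expected, an estimated a number 0.60 log units lower from compound 3 to compound 4 (beyond the scatter). The expected value for compound 4 is 2.4, within an estimated range of 2 to 2.8.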

Compound 4, distribution coefficient: 2.1
The estimate for compound 4 lay 0.30 log units above the measured number; the measured number falls inside the stated range.
By their numbers in this assay, from the lowest: compounds 1 and 4 (each within the scatter of the next); then compound 3; then compound 2.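

In this assay, compound 4 completes a pair that changes only at the carbonyl carbon of the propyl-bearing chain: hydroxy in place of dimethylamino gives a number 1.60 log units lower from compound 2 to compound 4 (beyond the scatter), a large step from the end group alone. The chain itself registers far less, as 1-carboxypropyl in place of 1-carboxyethyl on the nitrogen gives no change at the digits printed from compound 1 to compound 4 (within the scatter), while (1-carboxypropyl)amino in place of 2-carbamoylpropyl gives a number 0.90 log units lower from compound 3 to compound 4 (beyond the scatter), so among these compounds the two carboxy members stand together, clear of both amides. No independent measurement accompanies these numbers to account for them.

The compounds shown leave open where a primary carboxamide or a methyl ester on the same propyl-bearing chain would fall relative to compound 2 and compound 4, and whether a longer chain such as 1-carboxybutyl would still match the two carboxy compounds. They also leave the amino link and the carbon link unseparated, as compound 3 differs from compound 4 in both the link to the aromatic carbon and the end group at once.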